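Swapping Chloro for Acetyl: Expected Cytotoxicity of Compound 4

The source may report more compounds than this note shows. Statements on the series, on what has been measured and on what is new or still open speak of the compounds shown alone.

Measured in a functional assay on MCF7 cells (Homo sapiens) for cytotoxicity, read by MTT assay, with a stated time of 72 h; on this read-out higher numbers stand for weaker inhibition and lower numbers for stronger inhibition:
Compound 1, `O=C(CSC(=S)N[C@H]1CCOC1=O)Nc1ccc(Cl)cc1`, gives 50300 nM.
Compound 2, `Cc1cccc(NC(=O)CSC(=S)N[C@H]2CCOC2=O)c1C`, sits at the limit of > 128000 nM in this assay, at which 1 of the 3 values shown sits; its value > 128000 nM is a limit of the assay, not a number.
Compound 3, `O=C(CSC(=S)N[C@H]1CCOC1=O)Nc1ccc(Cl)cc1Cl`, gives 29200 nM.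

Compound 1 holds the highest of the two numbers; its nearest neighbour is compound 3, and the step of a 1.7-fold lower number from compound 1 to compound 3 (0.24 log units; within the scatter) lies within the scatter. Compound 4, `CC(=O)c1ccc(NC(=O)CSC(=S)N[C@H]2CCOC2=O)cc1`, differs from compound 1 by acetyl in place of chloro on an aromatic carbon. Among the compounds with values here, no measured step involves an acetyl group; the only measured step, a 1.7-fold lower number from compound 1 to compound 3 (0.24 log units; within the scatter), concerns chloro and stays within the scatter, so it offers no direction. The expected step of a 1.1-fold higher number from compound 1 to compound 4 (0.04 log units; within the scatter) in this assay is therefore small. Compound 4 is estimated at 55000 nM, with a range from 20000 nM to 150000 nM.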

Compound 4, half-maximal inhibitory concentration: > 128000 nM
Compound 4: no number, only a limit (the forecaster's own chance of this, stated with the estimate: 25%); middle value at least 2.3-fold (0.36 log units) away from the limit.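

In this assay, acetyl in place of chloro on an aromatic carbon, para to a large group, gives an at least 2.5-fold higher number from compound 1 to compound 4 (0.40 log units; beyond the scatter) and so, unlike the earlier chloro step, moves beyond the scatter. The group at this place can therefore change the read-out, and here the change runs towards weaker inhibition. Compound 4 gives no number, only a limit of the assay, and it shares that limit with compound 2: the limit of > 128000 nM in this assay, at which 2 of the 4 values shown sit.

On these data alone, how far compound 4 lies past this limit stays open, and so does the full size of its step. Also open, as far as these compounds go, is whether an amine or a carboxylic acid at this place would read like chloro or like acetyl.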